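Acetyl Capping of an Inactive Iodinated Nucleoside

The compounds below may be only part of what the source reports. "The series", "measured", "known", "first", "only" and "open" are said of these compounds alone.

Compound 1, `O=c1cc(I)n([C@@H]2O[C@H](CO)[C@@H](O)[C@H]2O)c(=O)[nH]1`, gives in a functional assay on COLO 205 cells (Homo sapiens) for antiproliferative activity, read by WST assay, with a stated time of 3 days (a lower number here means a stronger inhibitor, a higher number a weaker inhibitor), only the assay limit > 50000 nM.
Compound 2, `COC(=O)c1cc(=O)[nH]c(=O)n1[C@@H]1O[C@H](CO)[C@@H](O)[C@H]1O`, gives in this assay only the assay limit > 50000 nM.

Neither measured value is a number: both are limits, as the limit of > 50000 nM in this assay, at which 2 of the 2 values shown sit, records. Compound 1 therefore has no measured position beyond sitting at that limit. Among the measured compounds shown here, the one measured step, a step that the two limits leave unreadable from compound 1 to compound 2, is unreadable for the same reason, so its size cannot be taken as a guide.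

Compound 3, `CC(=O)OC[C@H]1O[C@@H](n2c(I)cc(=O)[nH]c2=O)[C@H](O)[C@@H]1O`, differs from compound 1 by acetyl in place of hydrogen on an oxygen on a saturated carbon. For the measured compounds named here, no measured step concerns a change on an oxygen on a saturated carbon; the only measured step changes an aromatic substituent and is itself unreadable. The expectation for compound 3 thus rests on the shared core alone, which in both measured compounds fails to reach a readable value.

Compound 3 is expected to give 80000 nM, in the range 30000 nM to 200000 nM. The step that the limit leaves unreadable from compound 1 to compound 3 is expected to be none beyond the scatter, with the measurement most likely ending again at a limit.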

Compound 3, half-maximal inhibitory concentration: > 50000 nM
Compound 3: only a limit was reported; the forecaster's own chance of this, stated with the estimate: 85%; the middle value does not contradict the limit.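

No step can be read between compound 1 and compound 3, as both results are limits and not numbers: the limit of > 50000 nM in this assay, at which 3 of the 3 values shown sit.

The compounds shown leave open how strongly compound 1, compound 2 and compound 3 act in this assay, and whether acetyl in place of hydrogen on that oxygen changes the result at all.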